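Three measured analogues and a threonine-side-chain variant

This account rests on a few compounds, and the source may have more. Where it says the series, first, only, none or still open, it means among the compounds named here.

The series shares a purine-type core carrying a cyclopropyl-substituted glycinamide linked to an amino acid benzyl ester. Compound 1 `O=C(CN(c1ncnc2c1ncn2C1CCCCO1)C1CC1)N[C@@H](CCC(=O)OCc1ccccc1)C(=O)OCc1ccccc1` is the glutamate dibenzyl ester with a tetrahydropyranyl group on the core. In a functional assay on the whole organism (Tail, strain ICR) with Mus musculus as the target, in the tail flick test, with a stated time of 60 min, at a dose of 25 umol/kg by the oral route (on this read-out higher numbers stand for a stronger effect at the one dose given and lower numbers for a weaker effect), compound 1 gives 34.7%. Compound 2 `O=C(OCc1ccccc1)[C@@H]1CCCN1C(=O)CN(c1nc(Cl)nc2[nH]cnc12)C1CC1` is the proline benzyl ester on a chloro-substituted core; in this assay compound 2 gives 34.4%. Compound 3 `NCCCC[C@H](NC(=O)CN(c1nc(Cl)nc2[nH]cnc12)C1CC1)C(=O)OCc1ccccc1` is the lysine benzyl ester on the same chloro-substituted core; in this assay compound 3 gives 41.2%. Compound 1 stands second highest of the three numbers, but all three values lie within the scatter of one another, so no order among them can be read.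

Compound 4 `C[C@@H](O)[C@H](NC(=O)CN(c1ncnc2c1ncn2C1CCCCO1)C1CC1)C(=O)OCc1ccccc1` has not been measured. It differs from compound 1 in one place: 1-hydroxyethyl in place of 2-(benzyloxycarbonyl)ethyl on a saturated chain carbon bound to an amide-type nitrogen and a carbonyl carbon

Among the measured compounds shown here, no pair of measured compounds differs in only one place, so no single step can be quantified from the data. The three measured side chains, although very different, give values within the scatter of each other, which gives no ground to expect a step from compound 1 to compound 4 in this assay beyond the scatter in either direction. The step from compound 1 to compound 4 is therefore estimated as a number 1.3 percentage points higher from compound 1 to compound 4 (within the scatter). For compound 4 in this assay the expected value is 36%, with an estimated range from 20% to 52%.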

Compound 4, a percentage reported as activity, at one dose (the size of the read-out at that dose, not a potency): 28.4%
Estimate against measurement, compound 4: 7.6 percentage points above, and the stated range covers the measured number.
By their numbers in this assay, from the lowest: compounds 4, 2, 1 and 3 (each within the scatter of the next, the first and the last beyond it).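

In this assay, among the compounds shown here, the first single-place step is a number 6.3 percentage points lower from compound 1 to compound 4 (within the scatter), with 1-hydroxyethyl in place of 2-(benzyloxycarbonyl)ethyl on a saturated chain carbon bound to an amide-type nitrogen and a carbonyl carbon. This step lies within the scatter, so the read-out at this one dose does not separate a group of 12 heavy atoms with a six-membered aromatic ring from one of 3 heavy atoms with no ring and with a hydrogen-bond donor; on this pair, the second benzyl ester is not required for an effect of this size. No measurement on these compounds bears on what lies behind this result.

Still open, from the compounds shown here alone, is how a carboxylic acid or a methyl group at this same place would read in this assay, since the two groups compared here give no trend that could be carried over to either. For the compounds shown here, compounds 2 and 3 differ from compounds 1 and 4 in more than one place, so no steps to them can be read, and the contribution of the core remains unresolved.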